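Isobutyl to butyl: compound 2 to compound 3

The compounds below may be only part of what the source reports. "The series", "measured", "known", "first", "only" and "open" are said of these compounds alone.

In a functional assay on CHO-K1 cells (Cricetulus griseus) for inhibition, read by MTT assay, with a stated time of 72 h (a higher number here means a weaker inhibitor, a lower number a stronger inhibitor), compound 2 `COc1cc(/C=C/C(=O)/C=C(/C=C/c2ccc(O)c(OC)c2)NCC(C)C)ccc1O` gives > 25000 nM, which is a limit and not a number. Compound 1 `CCCNC(=C\C(=O)/C=C/c1ccc(O)c(OC)c1)/C=C/c1ccc(O)c(OC)c1` gives > 25000 nM, also a limit. Among the compounds with values here, the one measured step, a step that the two limits leave unreadable from compound 1 to compound 2, offers no size to carry forward. Both values sit at the limit of > 25000 nM in this assay, at which 2 of the 2 values shown sit. Compound 3 `CCCCNC(=C\C(=O)/C=C/c1ccc(O)c(OC)c1)/C=C/c1ccc(O)c(OC)c1` differs from compound 2 by propyl in place of isopropyl on a saturated chain carbon bound to an amine nitrogen, which also reads as isobutyl to butyl. With no readable step as a guide, no change beyond the scatter is expected in this assay. The expected step is a step that the limit leaves unreadable from compound 2 to compound 3. The estimate for compound 3 is 30000 nM, with an expected range of 15000 nM to 60000 nM.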

Compound 3, half-maximal inhibitory concentration: 7000 nM
For compound 3 the middle estimate is 4.3-fold (0.63 log units) above the measured one, outside the stated range (below it).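

In this assay, the chain on the amine nitrogen now gives a first readable response, and it depends on how the same atoms are joined: isobutyl to butyl gives an at least 3.5-fold lower number from compound 2 to compound 3 (0.55 log units; beyond the scatter). Adding a methyl in place of hydrogen on a saturated chain carbon, three bonds along the chain from an amine nitrogen, gives an at least 3.5-fold lower number from compound 1 to compound 3 (0.55 log units; beyond the scatter). Both sizes are minimums, since compound 1 and compound 2 each carry a limit rather than a number: the limit of > 25000 nM in this assay, at which 2 of the 3 values shown sit.

The step between compound 1 and compound 2 cannot be read. As far as these compounds go, whether a pentyl or longer straight chain lowers the number further remains open.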